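Swapping Fluoro for Methoxy on a Sulfonamide

The compounds below may be only part of what the source reports. "The series", "measured", "known", "first", "only" and "open" are said of these compounds alone.

Compound 1 `O=[N+]([O-])c1ccc(S(=O)(=O)Nc2cccc3c(Cl)c[nH]c23)cc1`: 14 ug/mL
Compound 2 `Nc1ccc(S(=O)(=O)Nc2ccc(F)c3c(Cl)c[nH]c23)cc1`: 14 ug/mL

In a functional assay on KB cells (Homo sapiens) for antiproliferative activity, read by colorimetric assay and MTT assay (on this read-out higher numbers stand for weaker inhibition and lower numbers for stronger inhibition), compound 2 gives 14 ug/mL, level with compound 1 at 14 ug/mL, so the two cannot be told apart within the usual scatter of this kind of measurement. The next compound to be tested, compound 3 `COc1ccc(NS(=O)(=O)c2ccc(N)cc2)c2[nH]cc(Cl)c12`, keeps the core of compound 2 and carries methoxy in place of fluoro on an aromatic carbon, para to a large group (methoxy in place of fluoro on an aromatic carbon). Within the data shown here, no two measured compounds differ in one place only, so no measured step shows how large this swap might be, and any forecast is uncertain. In this assay the estimated change a 1.4-fold lower number from compound 2 to compound 3 (0.15 log units; within the scatter) is expected to stay within the scatter. For compound 3 the expected value is 10 ug/mL, with an estimated range of 3 ug/mL to 30 ug/mL.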

Compound 3, half-maximal inhibitory concentration: 20 ug/mL
Compound 3: middle estimate off by 2.0-fold (0.30 log units), on the low side; low and high end bracket the measured number.
By their numbers in this assay, from the lowest: compounds 1, 2 and 3 (each within the scatter of the next).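

In this assay, replacing fluoro with methoxy gives a 1.4-fold higher number from compound 2 to compound 3 (0.15 log units; within the scatter), so on this aromatic carbon, para to a large group, the two groups cannot be told apart. Methoxy has more heavy atoms than fluoro and counts as a hydrogen-bond acceptor where fluoro does not, yet this pair shows no change beyond the scatter. Nothing measured here offers a reason for this result.

As far as these compounds go, it remains open whether an amine, a carboxylic acid or a longer chain such as butoxy at this position would move the number beyond the scatter. From the compounds shown here alone, the swap is also seen in this one pair only, so whether it would read the same with a nitro group in place of the amine on the other ring remains unknown.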